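The source may report more compounds than this note shows. Statements on the series, on what has been measured and on what is new or still open speak of the compounds shown alone.

Compound 1 `CC(=O)c1ccc(NC(=O)Nc2cc(C)nc3ccccc23)cc1` gives 3800 nM
Compound 2 `COc1ccc(NC(=O)Nc2cc(C)nc3ccccc23)cc1OC` gives 4100 nM
Compound 3 `Cc1cc(NC(=O)Nc2cc(F)cc(F)c2)c2ccccc2n1` gives 300 nM

These three values, all from a physicochemical assay for solubility, at pH 7.4 (on this read-out higher numbers stand for higher solubility and lower numbers for lower solubility), are everything measured so far. Compound 1 and compound 2 lie within the scatter of each other, while compound 3 lies far lower, beyond the scatter. Compound 1 therefore stands at the upper end of this small set, level with compound 2.

The step followed here leads from compound 1 to compound 4 `Cc1cc(NC(=O)Nc2ccc(OC(F)(F)F)cc2)c2ccccc2n1`, which has not yet been measured. It places trifluoromethoxy in place of acetyl on an aromatic carbon, para to a large group (trifluoromethoxy in place of acetyl on an aromatic carbon).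

For the measured compounds named here, no measured pair differs in one place only, so no direct precedent exists. Going by the values given here, the only guide is thin: compound 3 (300 nM) is the one measured compound that carries fluorine, whereas compound 1 (3800 nM) and compound 2 (4100 nM) carry none. Three compounds cannot establish a rule. Even so, a fall in this assay beyond the scatter is expected, with a 6.3-fold lower number from compound 1 to compound 4 (0.80 log units; beyond the scatter) as the estimated step. The expected value for compound 4 is 600 nM (estimated range 120 nM to 3000 nM).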

Compound 4, solubility: 300 nM
Compound 4: middle estimate off by 2.0-fold (0.30 log units), on the high side; the measured number falls inside the stated range.
By their numbers in this assay, from the lowest: compounds 3 and 4 (each within the scatter of the next); then compounds 1 and 2 (each within the scatter of the next).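

Read in this assay the exchange of acetyl for trifluoromethoxy on this aromatic carbon, para to a large group, gives a 13-fold lower number from compound 1 to compound 4 (1.10 log units; beyond the scatter) and is the first measured case in this set of a change in one place alone. It shows that this position is not indifferent to the group it carries, since the rest of compound 1 stays the same while the number moves well beyond the scatter, even though the leaving and entering groups have the same counts of hydrogen-bond donors and acceptors and neither has a net charge. What remains different between the two groups is their composition: trifluoromethoxy has more heavy atoms and brings fluorine, while acetyl has a double bond, and no measurement available here accounts for the fall.

This single pair cannot separate the loss of the carbonyl from the arrival of the fluorine atoms or the larger heavy-atom count. It also leaves open where an amine, a carboxylic acid or a longer chain at this position would stand relative to acetyl and trifluoromethoxy.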